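This account rests on a few compounds, and the source may have more. Where it says the series, first, only, none or still open, it means among the compounds named here.

Working notes on the series. For the measured compounds named here, compound 2 `Cc1cccc(/C(N)=N/NC(=S)N2CCSCC2)n1` gives in a functional assay on MCF7 cells (Homo sapiens) for cytotoxicity, read by MTT assay, with a stated time of 72 h, tested at 3 uM (a lower number here means less inhibition of growth, a higher number more inhibition of growth at the concentration tested), a value of 20.6%, the lowest of the three numbers so far; compound 3 `N/C(=N\NC(=S)N1CCSCC1)c1ccccn1` gives 29%, a gap within the scatter, while compound 1 `N/C(=N\NC(=S)N1CCOCC1)c1ccccn1` gives 44.5%, a gap beyond it. The change under study is morpholin-4-yl in place of thiomorpholin-4-yl on a thiocarbonyl carbon, leading to compound 4 `Cc1cccc(/C(N)=N/NC(=S)N2CCOCC2)n1`. Going by the values given here, two measured steps bear on it. The step of a number 15.5 percentage points lower from compound 1 to compound 3 (beyond the scatter) is the same exchange run the other way, and the step of a number 8.4 percentage points higher from compound 2 to compound 3 (within the scatter) lies within the scatter, so the methyl on the aromatic carbon of compound 2 is taken as neutral for this comparison. The reverse of the exchange seen from compound 1 to compound 3 is therefore expected to raise the number by a comparable amount. For compound 4 the expected step is a number 15.4 percentage points higher from compound 2 to compound 4 (beyond the scatter). Compound 4 is accordingly estimated at 36%, within a range from 24% to 48%.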

Compound 4, percent growth inhibition at one concentration: 21.6%
The estimate for compound 4 lay 14.4 percentage points above the measured number; the whole stated range lies above it.
By their numbers in this assay, from the lowest: compounds 2, 4 and 3 (each within the scatter of the next); then compound 1.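

In this assay, morpholin-4-yl in place of thiomorpholin-4-yl on a thiocarbonyl carbon does not behave alike on the two cores. With the methyl on the aromatic carbon present, the step is a number 1 percentage points higher from compound 2 to compound 4 (within the scatter), so the exchange that mattered without the methyl does not show here: the same change on two cores in this assay, a number 15.5 percentage points lower (beyond the scatter) from compound 1 to compound 3 and a number 1 percentage points lower (within the scatter) from compound 4 to compound 2, 14.5 percentage points apart, beyond the scatter of two such steps. The methyl can no longer be taken as neutral, since with morpholin-4-yl in place the step is a number 22.9 percentage points lower from compound 1 to compound 4 (beyond the scatter), and its size depends on the group on the thiocarbonyl carbon: the same change on two cores in this assay, a number 8.4 percentage points higher (within the scatter) from compound 2 to compound 3 and a number 22.9 percentage points higher (beyond the scatter) from compound 4 to compound 1, 14.5 percentage points apart, beyond the scatter of two such steps.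

Compound 1 alone stands apart from the other three compounds, and the two changes do not add up. Open, from the compounds shown here alone, is whether a chloro or methoxy group on that aromatic carbon would give the same drop as methyl, and how a piperidin-1-yl or dimethylamino group on the thiocarbonyl carbon would read on either core.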